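The compounds below may be only part of what the source reports. "The series", "measured", "known", "first", "only" and "open" are said of these compounds alone.

Working notes on the series. In a functional assay on MCF7 cells (Homo sapiens) for cytotoxicity (on this read-out higher numbers stand for weaker inhibition and lower numbers for stronger inhibition), compound 1 (`CCC(CO)Nc1nc(NCc2ccccc2)c2nc(Cl)n(C(C)C)c2n1`) gives 54000 nM and compound 2 (`CCC(CO)Nc1nc(NCc2ccccc2)c2nc(Br)n(C(C)C)c2n1`) gives 53000 nM. Bromo in place of chloro on an aromatic carbon amounts to a 1.0-fold lower number from compound 1 to compound 2 (0.01 log units; within the scatter), so compound 2 does not separate from the only other measured number. Compound 3 (`CCC(CO)Nc1nc(NCc2ccccc2)c2nc(N)n(C(C)C)c2n1`) carries this change: amino in place of bromo on an aromatic carbon. This puts amino in place of bromo on an aromatic carbon, between two ring nitrogen atoms. For the measured compounds named here, the one measured step at this place exchanges one halogen for another, and no measured step covers an amino group, so the evidence is thin and the range must stay wide. The expected step in this assay is a 1.3-fold lower number from compound 2 to compound 3 (0.12 log units; within the scatter), which means none beyond the scatter. For compound 3 the estimate is 40000 nM, with an expected range from 15000 nM to 100000 nM.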

Compound 3, half-maximal inhibitory concentration: 60000 nM
Compound 3: the middle estimate sits 1.5-fold (0.18 log units) below what was measured, within the range that was stated.
By their numbers in this assay, from the lowest: compounds 2, 1 and 3 (each within the scatter of the next).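

At this position, on an aromatic carbon of a five-membered aromatic ring with 2 nitrogen, amino does not separate from either halogen in this assay: the steps are a 1.1-fold higher number from compound 2 to compound 3 (0.05 log units; within the scatter) and a 1.1-fold higher number from compound 1 to compound 3 (0.05 log units; within the scatter). The earlier pair exchanged only one halogen for another, whereas this change also brings in a hydrogen-bond donor and a hydrogen-bond acceptor by count, and the number still stays within the scatter. Nothing available offers a reason for this flat result.

The compounds shown leave open whether a group such as methoxy, dimethylamino or phenyl at this position would separate from these three. They also leave open whether a plain hydrogen there would do so, and whether the same insensitivity would hold with another group in place of the benzylamino substituent.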